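The compounds below may be only part of what the source reports. "The series", "measured", "known", "first", "only" and "open" are said of these compounds alone.

Compound 2 `CCCCCCCCCCCCCCNC(=O)[C@H](CO)/N=C/c1ccccc1O` and compound 1 `CCCCCCCCCCCCCCNC(=O)[C@H](CO)/N=C/c1ccccc1Cl` share one core and differ only in the group on the aromatic ring. In an ADME assay on HEK293 cells (Homo sapiens) for cytotoxicity (a lower number here means a stronger inhibitor, a higher number a weaker inhibitor), compound 1 gives 94900 nM, and in this assay compound 2 gives 80800 nM. Compound 2 thus holds the lower of the two numbers, but the gap to compound 1 is small: a 1.2-fold lower number from compound 1 to compound 2 (0.07 log units; within the scatter). The next compound, compound 3 `CCCCCCCCCCCCCCNC(=O)[C@H](CO)/N=C/c1ccccc1C`, is reached by one change: methyl in place of hydroxy on an aromatic carbon. Among the measured compounds shown here, the only measured step at this position, from compound 1 to compound 2, stayed within the scatter, so there is no sign yet that this position moves the number in this assay. The expectation for compound 3 is therefore a step no larger than the scatter, a 1.1-fold higher number from compound 2 to compound 3 (0.04 log units; within the scatter). Compound 3 is estimated at 88000 nM in this assay, with a range from 44000 nM to 176000 nM.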

Compound 3, half-maximal inhibitory concentration: 81100 nM
For compound 3 the middle estimate is 1.1-fold (0.04 log units) above the measured one; low and high end bracket the measured number.
By their numbers in this assay, from the lowest: compounds 2, 3 and 1 (each within the scatter of the next).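

Hydroxy carries a hydrogen-bond donor and acceptor and methyl carries neither, yet exchanging them in this assay gives a 1.0-fold higher number from compound 2 to compound 3 (0.00 log units; within the scatter). Methyl in place of chloro gives a 1.2-fold lower number from compound 1 to compound 3 (0.07 log units; within the scatter), so compounds 1, 2 and 3 all lie within the scatter of one another, and no group among chloro, hydroxy and methyl on this aromatic carbon stands apart. Nothing available explains this flat result or bears on it.

The compounds shown leave open whether an amine, a carboxylic acid or a larger group such as phenyl on this aromatic carbon would give a step beyond the scatter. They also leave open whether the number responds to other parts of the molecule, such as a shorter chain in place of the long one, since that chain is the same in compounds 1, 2 and 3.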